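Thiourea-sulfonamide series: nitro for methoxy on the aryl thiourea

The source may hold more compounds than are shown below. What is called first, only, known or untested is meant among the compounds shown, and "the series" means these compounds.

Two compounds of this series have been run in a functional assay on RS4-11 cells (Homo sapiens) for inhibition, read by CCK-8 assay, with a stated time of 48 h; on this read-out lower numbers stand for stronger inhibition and higher numbers for weaker inhibition. Compound 1 `O=S(=O)(NCCNC(=S)Nc1cc(C(F)(F)F)cc(C(F)(F)F)c1)c1ccc(-c2ccccc2OCc2ccccc2)s1` reaches only the assay limit, > 50000 nM, which is a limit and not a number. For the measured compounds named here, compound 2 `COc1ccc(NC(=S)NCCNS(=O)(=O)c2sccc2-c2ccc(C)cc2Oc2ccc(O)c(O)c2)cc1` gives 8300 nM in this assay and so stands as the only numerical value in hand. The other value recorded belongs to compound 1 and is the limit (the limit of > 50000 nM in this assay, at which 1 of the 2 values shown sits). Going by the values given here, no step between measured compounds differing in one place is available, so no measured change anchors the next move.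

Compound 3 `Cc1ccc(-c2ccsc2S(=O)(=O)NCCNC(=S)Nc2cccc([N+](=O)[O-])c2)c(Oc2ccc(O)c(O)c2)c1` follows from compound 2 by the change (3-nitrophenyl in place of 4-methoxyphenyl on an amide-type nitrogen). Among the compounds with values here, with no comparable measured step to draw on, the expectation is a step of no more than the usual scatter, in either direction: the step from compound 2 to compound 3 is estimated at a 1.0-fold lower number from compound 2 to compound 3 (0.02 log units; within the scatter). Compound 3 is therefore expected to give about 8000 nM in this assay, with a range from 2500 nM to 25000 nM.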

Compound 3, half-maximal inhibitory concentration: 6100 nM
The estimate for compound 3 lay 1.3-fold (0.12 log units) above the measured number; the range from low to high includes it.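

In this assay, the step at this position, an amide-type nitrogen whose other neighbour is the thiocarbonyl carbon, is a 1.4-fold lower number from compound 2 to compound 3 (0.13 log units; within the scatter). For the compounds shown here, this is the first one-place comparison, and this read-out does not tell the two compounds apart. At this position, then, 3-nitrophenyl and 4-methoxyphenyl are interchangeable on this read-out, though a single pair supports no wider rule, and no measured property in hand bears on this step.

Going by these compounds, a single exchange changes both the substituent and where it sits on the ring, so the contribution of each stays open. Also open, on these data alone, is how this read-out would respond to an unsubstituted phenyl, or to an amine or a carboxylic acid on this ring, at the same nitrogen.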